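This account rests on a few compounds, and the source may have more. Where it says the series, first, only, none or still open, it means among the compounds named here.

Compound 1, `O=C(/C=C/C1=Cc2ccccc2OC1)c1ccc(Cl)cc1`, gives in a functional assay on the whole organism for inhibition, with Mus musculus as the target, with a stated time of 1 h, at a dose of 30 mg/kg by the intraperitoneal route (a higher number here means more inhibition at the dose given (going by the name of the read-out), a lower number less inhibition), a reading of 56.1%. Compound 2, `COc1ccc(C(=O)/C=C/C2=Cc3ccccc3OC2)cc1`, gives in this assay a reading of 66.2%.

Among the measured compounds shown here, on these two numbers compound 2 stands highest: its nearest neighbour is compound 1, and the one measured step, a number 10.1 percentage points higher from compound 1 to compound 2 (beyond the scatter), separates them. For the measured compounds named here, that step is a single change on an aromatic carbon of the shared core, and it is the only comparison in hand.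

Compound 3, `CN(C)c1ccc(C(=O)/C=C/C2=Cc3ccccc3OC2)cc1`, has not yet been measured in this assay. It differs from compound 2 by dimethylamino in place of methoxy on an aromatic carbon. Going by the values given here, no measured pair shows this particular exchange, so the step from compound 1 to compound 2 is the only guide, and it speaks only to a replacement at the same aromatic carbon, not to the group that now enters. Compound 3 is therefore expected to lie close to compound 2, with a step of a number 3.8 percentage points higher from compound 2 to compound 3 (within the scatter) estimated, which may fall within the usual scatter. Compound 3 is estimated at 70% in this assay, with a range from 52% to 86%.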

Compound 3, a percentage reported as inhibition, in the whole organism at one dose (the size of the read-out at that dose, not a potency): 57.3%
Estimate against measurement, compound 3: 12.7 percentage points above, and the stated range covers the measured number.
By their numbers in this assay, from the lowest: compounds 1, 3 and 2 (each within the scatter of the next, the first and the last beyond it).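

Putting dimethylamino in place of methoxy gives a number 8.9 percentage points lower from compound 2 to compound 3 (within the scatter) in this assay and putting dimethylamino in place of chloro gives a number 1.2 percentage points higher from compound 1 to compound 3 (within the scatter) on the same aromatic carbon, para to a large group, so the new group cannot be told apart from either of the two earlier ones. The gap between compound 1 and compound 2 remains the only one here beyond the scatter, so with a third group in hand this position shows one readable difference, and compound 3 takes no clear place in any order of the three. Nothing available offers an explanation for these readings.

Going by these compounds, whether a hydroxy group, a fluoro group, a longer chain such as ethoxy, or a larger amine such as piperidine on this carbon would read apart from these three groups remains open. Also open, on these data alone, is how any of the three compounds would behave in this assay at other doses, since each reading here comes from a single dose and a single time.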